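The source may report more compounds than this note shows. Statements on the series, on what has been measured and on what is new or still open speak of the compounds shown alone.

Compound 1 `O=CN1N=C(c2ccc(F)cc2)CC1c1cn(-c2ccccc2)nc1-c1ccc(Cl)c(Cl)c1`: 37.2%
Compound 2 `CC(=O)N1N=C(c2ccc(C)cc2)CC1c1cn(-c2ccccc2)nc1-c1ccc(Cl)c(Cl)c1`: 27.7%
Compound 3 `O=CN1N=C(c2ccc(Cl)cc2)CC1c1cn(-c2ccccc2)nc1-c1ccc(Cl)c(Cl)c1`: 35.1%

All three numbers come from a functional assay on the whole organism (strain Wistar) for inhibition, with Rattus norvegicus as the target, read by paw edema, with a stated time of 30 min, at a dose of 50 mg/kg by the oral route; a higher number here means more inhibition at the dose given (going by the name of the read-out), a lower number less inhibition. Compound 1 holds the highest of the three, yet compound 3 and compound 2 both sit within the scatter of it, so no order among them can be claimed. For the measured compounds named here, the only step that changes one place, a number 2.1 percentage points lower from compound 1 to compound 3 (within the scatter), also stays within the scatter. Compound 4 `CCC(=O)N1N=C(c2ccc(F)cc2)CC1c1cn(-c2ccccc2)nc1-c1ccc(Cl)c(Cl)c1` differs from compound 1 by ethyl in place of hydrogen on a carbonyl carbon. Going by the values given here, no measured step alters only this position: compound 2 differs from compound 1 in two places, not one, and its value stays within the scatter of compound 1. The step expected for this change, a number 6.2 percentage points lower from compound 1 to compound 4 (within the scatter), is therefore small. Compound 4 is estimated at 31%, with a range from 18% to 44%.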

Compound 4, a percentage reported as inhibition, in the whole organism at one dose (the size of the read-out at that dose, not a potency): 51.1%
For compound 4 the middle estimate is 20.1 percentage points below the measured one; measured number above the stated range.
By their numbers in this assay, from the lowest: compounds 2, 3 and 1 (each within the scatter of the next); then compound 4.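

For the compounds shown here, replacing the hydrogen on the carbonyl carbon with ethyl, the change from formyl to propanoyl, gives in this assay the only single-place step beyond the scatter: a number 13.9 percentage points higher from compound 1 to compound 4 (beyond the scatter). Going by these compounds alone, the group on this carbonyl carbon therefore matters to the read-out, whereas the one earlier step, on an aromatic carbon, stayed within the scatter. No measurement here explains the rise.

One step cannot show whether a longer chain such as butanoyl would raise the number further. It also leaves open whether a carbonyl carrying an amine would keep the gain.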